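The compounds below may be only part of what the source reports. "The series", "measured", "known", "first", "only" and "open" are said of these compounds alone.

In an ADME assay on the whole organism (Rattus norvegicus, strain Sprague-Dawley) for pharmacokinetics, read by LC-MS, at a dose of 2 mg/kg by the oral route (a lower number here means that a smaller share of the oral dose reaches the circulation, a higher number that a larger share of the oral dose reaches the circulation), compound 1 (`N#Cc1ccc(S(=O)(=O)N2C[C@H](S(=O)(=O)c3ccc(Cl)cn3)[C@](O)(CO)C2)c(Cl)c1`) gives 62% and compound 2 (`N#Cc1ccc(S(=O)(=O)N2C[C@H](S(=O)(=O)c3ccc(Cl)cn3)[C@](O)(CN)C2)c(Cl)c1`) gives 64% and so stands level with compound 1 within the scatter. The change to compound 3 (`N#Cc1ccc(S(=O)(=O)N2C[C@H](S(=O)(=O)c3ccc(Cl)cn3)[C@@](O)(CN)C2)c(Cl)c1`), which has not yet been measured, is a matter of configuration alone (the two compounds have the same atoms and bonds and differ only in configuration as drawn: 1 of 2 stereo elements differ; a stereocentre at a saturated ring carbon is drawn S in compound 2 and R in compound 3) and involves no exchange of groups. Going by the values given here, the one measured step (a number 2 percentage points higher from compound 1 to compound 2 (within the scatter)) puts amino in place of hydroxy on a saturated chain carbon, stays within the scatter and bears on this change only indirectly. Among the compounds with values here, no measured pair shows what a change of configuration does here, so no direction can be given and only a loose expectation is possible. For compound 3 the expected step (a number 4 percentage points lower from compound 2 to compound 3 (within the scatter)) is none beyond the scatter. In this assay compound 3 is estimated at 60% (expected range 35% to 80%).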

Compound 3, oral bioavailability: 56%
Beside the measured number, compound 3's estimate is 4 percentage points above it, within the range that was stated.
By their numbers in this assay, from the lowest: compounds 3, 1 and 2 (each within the scatter of the next).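

In this assay, going by these compounds alone, the first change of configuration seen at this saturated ring carbon gives a number 8 percentage points lower from compound 2 to compound 3 (within the scatter). The earlier compounds shown here showed only an exchange of groups on the chain carbon, whereas this pair shows that, with the amino group in place, the S and R drawings of this stereocentre cannot be told apart by this measure. The comparison isolates that one stereocentre: the fact that compounds 2 and 3 differ only in the configuration as drawn.

The compounds shown leave open whether the same holds when the hydroxy group of compound 1 sits on the chain carbon in place of the amino group, and what a change at the other stereocentre would do. They also leave open whether a carboxylic acid, an amide or a longer chain at this position would stay level with these compounds in this assay.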